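Methyl for chloro on the aryl of a pyrazoline core

The source may report more compounds than this note shows. Statements on the series, on what has been measured and on what is new or still open speak of the compounds shown alone.

Measured so far in a functional assay on the whole organism (strain Wistar) for inhibition, with Rattus norvegicus as the target, read by paw edema, with stated times of 30 min and 60 min, at a dose of 50 mg/kg by the oral route; a lower number here means less inhibition, a higher number more inhibition at the dose given (going by the name of the read-out):
compound 1 `CCC(=O)N1N=C(c2ccc(C)cc2)CC1c1cn(-c2ccccc2)nc1-c1ccc(Cl)c(Cl)c1` gives 61.1%
compound 2 `O=CN1N=C(c2ccc(F)cc2)CC1c1cn(-c2ccccc2)nc1-c1ccc(Cl)c(Cl)c1` gives 56.5%
compound 3 `O=CN1N=C(c2ccc(Cl)cc2)CC1c1cn(-c2ccccc2)nc1-c1ccc(Cl)c(Cl)c1` gives 51.1%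

Compound 3 stands lowest of the three numbers, but its gap to compound 2 and its gap to compound 1 both lie within the scatter, so nothing separates them with confidence. For the measured compounds named here, the only single-point step among the measured compounds is a number 5.4 percentage points lower from compound 2 to compound 3 (within the scatter), and it did not move the read-out beyond the scatter.

Compound 4 `Cc1ccc(C2=NN(C=O)C(c3cn(-c4ccccc4)nc3-c3ccc(Cl)c(Cl)c3)C2)cc1` is not yet measured. It differs from compound 3 as follows: methyl in place of chloro on an aromatic carbon. Going by the values given here, no measured step swaps chloro for methyl at this place. Compound 1 also carries the 4-methylphenyl group, with a different acyl group on the shared core, and it gives 61.1%; compound 3 gives 51.1%. Given that the one halogen-for-halogen step stayed within the scatter, compound 4 is expected to move little: the step of a number 3.9 percentage points higher from compound 3 to compound 4 (within the scatter) is estimated to stay within the scatter, with a slight lean upward. Compound 4 is thus expected to give about 55%, with a range from 44% to 66%.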

Compound 4, a percentage reported as inhibition, in the whole organism at one dose (the size of the read-out at that dose, not a potency): 53.4%
The estimate for compound 4 lay 1.6 percentage points above the measured number; the measured number falls inside the stated range.
By their numbers in this assay, from the lowest: compounds 3, 4, 2 and 1 (each within the scatter of the next).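

In this assay, methyl in place of chloro on the aromatic carbon gives a number 2.3 percentage points higher from compound 3 to compound 4 (within the scatter), the first test of a group other than a halogen at this place, para to a large group. Methyl in place of fluoro gives a number 3.1 percentage points lower from compound 2 to compound 4 (within the scatter), so with the acyl group held as formyl, neither exchange involving methyl at this position moves the read-out beyond the scatter. With the 4-methylphenyl group now held constant, hydrogen in place of ethyl on the carbonyl carbon gives a number 7.7 percentage points lower from compound 1 to compound 4 (within the scatter), so this acyl difference also stays within the scatter.

Nothing available explains why these exchanges leave the read-out within the scatter. From the compounds shown here alone, whether an amine or a carboxylic acid at this place, or a longer chain on the carbonyl carbon, would carry the read-out beyond the scatter remains open.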